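Para-substituent variation on the pendant phenyl ring

The source may report more compounds than this note shows. Statements on the series, on what has been measured and on what is new or still open speak of the compounds shown alone.

Measured compounds:
compound 1 `O=Cc1c(-c2ccc(F)cc2)nc2sc(Cc3ccc(Cl)cc3)nn12`; in an ADME assay on CCRF-CEM cells (Homo sapiens) for cytotoxicity, with a stated time of 72 h (on this read-out lower numbers stand for stronger inhibition and higher numbers for weaker inhibition), compound 1 gives 17000 nM
compound 2 `O=Cc1c(-c2ccc(Cl)cc2)nc2sc(Cc3ccc(Cl)cc3)nn12`; in this assay compound 2 gives 5800 nM
compound 3 `COc1ccc(-c2nc3sc(Cc4ccc(Cl)cc4)nn3c2C=O)cc1`; in this assay compound 3 gives 3800 nM

Compound 3 carries the lowest number of the three. Against compound 1 the gap is clear, a 4.5-fold lower number from compound 1 to compound 3 (0.65 log units; beyond the scatter); against compound 2 it is not, a 1.5-fold lower number from compound 2 to compound 3 (0.18 log units; within the scatter), so compounds 2 and 3 cannot be separated on these numbers.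

Compound 4 `O=Cc1c(-c2ccc([N+](=O)[O-])cc2)nc2sc(Cc3ccc(Cl)cc3)nn12` is not yet measured. Relative to compound 3 the change is nitro in place of methoxy on an aromatic carbon.

For the measured compounds named here, no measured step exchanges methoxy for nitro, so the bearing of the existing steps is indirect. They show that varying the group at this position shifts the read-out by modest amounts: a 2.9-fold lower number from compound 1 to compound 2 (0.47 log units; beyond the scatter) and a 4.5-fold lower number from compound 1 to compound 3 (0.65 log units; beyond the scatter), while a 1.5-fold lower number from compound 2 to compound 3 (0.18 log units; within the scatter) stays within the scatter. A step of comparable modest size in either direction is therefore the likely outcome, with no firm basis to expect a large shift.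

Compound 4 is estimated at 4000 nM, with a range from 1500 nM to 12000 nM. The expected step is a 1.1-fold higher number from compound 3 to compound 4 (0.02 log units; within the scatter), essentially no change beyond the scatter.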

Compound 4, half-maximal inhibitory concentration: 13000 nM
Beside the measured number, compound 4's estimate is 3.3-fold (0.51 log units) below it; the measured number lies above the stated range.
By their numbers in this assay, from the lowest: compounds 3 and 2 (each within the scatter of the next); then compounds 4 and 1 (each within the scatter of the next).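

In this assay the change from methoxy to nitro gives a 3.4-fold higher number from compound 3 to compound 4 (0.53 log units; beyond the scatter), and the change from chloro to nitro gives a 2.2-fold higher number from compound 2 to compound 4 (0.35 log units; beyond the scatter), so the close agreement of compounds 2 and 3 does not extend to every replacement of fluoro on this aromatic carbon. The remaining comparison, a 1.3-fold lower number from compound 1 to compound 4 (0.12 log units; within the scatter), leaves nitro and fluoro inseparable, and the four compounds now form two sets, compounds 2 and 3 on one side and compounds 1 and 4 on the other, with every step across the two sets beyond the scatter. No measurement available here accounts for this division.

From the compounds shown here alone, it remains open whether an amine, a hydroxyl group or a carboxylic acid on this aromatic carbon would fall with compounds 2 and 3, with compounds 1 and 4, or outside both sets. Going by these compounds, it is also open whether the same division would persist if the 4-chlorobenzyl group on the shared core were replaced by a longer alkyl chain.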